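Changing the halogens on the aryl ketone of compound 3

The compounds below may be only part of what the source reports. "The series", "measured", "known", "first", "only" and "open" are said of these compounds alone.

Compound 1 `CC1(C)S[C@@H]2/C(=C\C(=O)c3ccc(C(F)(F)F)cc3)C(=O)N2[C@H]1C(=O)OC(c1ccccc1)c1ccccc1`: 26700 nM
Compound 2 `CC1(C)S[C@@H]2/C(=C\C(=O)OCc3ccccc3)C(=O)N2[C@H]1C(=O)OC(c1ccccc1)c1ccccc1`: 7100 nM
Compound 3 `CC1(C)S[C@@H]2/C(=C\C(=O)c3ccc(Cl)cc3)C(=O)N2[C@H]1C(=O)OC(c1ccccc1)c1ccccc1`: 48600 nM

In a functional assay on A-375 cells (Homo sapiens) for cytotoxicity, read by MTT assay, with a stated time of 48 h (a higher number here means a weaker inhibitor, a lower number a stronger inhibitor), compound 3 gives the highest of the three numbers; its step to compound 1 is within the scatter, while a 6.8-fold higher number from compound 2 to compound 3 (0.84 log units; beyond the scatter) is the only gap beyond it. Compound 4 `CC1(C)S[C@@H]2/C(=C\C(=O)c3cc(F)cc(F)c3)C(=O)N2[C@H]1C(=O)OC(c1ccccc1)c1ccccc1` differs from compound 3 in one place: 3,5-difluorophenyl in place of 4-chlorophenyl on a carbonyl carbon. The step that bears on this change is a 1.8-fold higher number from compound 1 to compound 3 (0.26 log units; within the scatter), which swapped one aryl substituent for another and stayed within the scatter; the larger steps of a 3.8-fold lower number from compound 1 to compound 2 (0.58 log units; beyond the scatter) and a 6.8-fold higher number from compound 2 to compound 3 (0.84 log units; beyond the scatter) concern the benzyloxy group and do not apply here. A step of no more than the scatter is therefore expected, a 1.4-fold lower number from compound 3 to compound 4 (0.13 log units; within the scatter). Compound 4 is estimated at 36000 nM, ranging from 12000 nM to 100000 nM.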

Compound 4, half-maximal inhibitory concentration: 19100 nM
Beside the measured number, compound 4's estimate is 1.9-fold (0.28 log units) above it, within the range that was stated.
By their numbers in this assay, from the lowest: compound 2; then compounds 4, 1 and 3 (each within the scatter of the next, the first and the last beyond it).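

In this assay, this position on the carbonyl carbon proves sensitive to the aryl halogens, with a 2.5-fold lower number from compound 3 to compound 4 (0.41 log units; beyond the scatter). The gain has limits: the benzyloxy group still gives the lower number, at a 2.7-fold higher number from compound 2 to compound 4 (0.43 log units; beyond the scatter), while the 4-(trifluoromethyl)phenyl ketone cannot be told apart from the 3,5-difluorophenyl ketone, at a 1.4-fold lower number from compound 1 to compound 4 (0.15 log units; within the scatter). No accompanying measurement explains these steps. The compounds shown leave open whether the step depends on the number of fluorines or on where they sit, and how an aryl ring carrying a single fluorine or an amine would behave.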